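A few compounds are considered here, and "the series" means these few. Any claim that something is new, unique, unknown or untested is made for them only; others in the source may bear on it.

Measured so far in a functional assay on HT-29 cells (Homo sapiens) for antiproliferative activity, read by MTT assay, with a stated time of 72 h; on this read-out lower numbers stand for stronger inhibition and higher numbers for weaker inhibition:
compound 1 `COc1ccc(N2CCN(C(=S)SCc3ccc4nc(N)nc(N)c4c3)CC2)cc1` gives 1770 nM
compound 2 `Nc1nc(N)c2cc(CSC(=S)N3CCN(c4ccc(Cl)cc4)CC3)ccc2n1` gives 7480 nM

Within the data shown here, compound 2 stands at the higher of the two numbers; its nearest neighbour is compound 1, and the one recorded step between them, a 4.2-fold higher number from compound 1 to compound 2 (0.63 log units; beyond the scatter), is modest though beyond the scatter. It swaps one group on the aryl ring that hangs from the ring nitrogen of the shared core.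

Compound 3 `Nc1nc(N)c2cc(CSC(=S)N3CCN(c4ccc(F)cc4F)CC3)ccc2n1` differs from compound 2 as follows: 2,4-difluorophenyl in place of 4-chlorophenyl on an amine nitrogen in a ring. Among the measured compounds shown here, the only step that bears on this is the one above, since it also alters the substituent pattern of that same aryl ring; its size was modest. For the measured compounds named here, no step with a fluorine-bearing ring exists in the set, so the direction is open. A step of no more than modest size in either direction, likely within the scatter, is expected, a 1.4-fold lower number from compound 2 to compound 3 (0.13 log units; within the scatter). Compound 3 is therefore estimated at 5500 nM, with a range of 1800 nM to 17000 nM.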

Compound 3, half-maximal inhibitory concentration: 5020 nM
Compound 3: middle estimate off by 1.1-fold (0.04 log units), on the high side, within the range that was stated.
By their numbers in this assay, from the lowest: compound 1; then compounds 3 and 2 (each within the scatter of the next).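

Putting 2,4-difluorophenyl in place of 4-chlorophenyl on the ring amine nitrogen gives a 1.5-fold lower number from compound 2 to compound 3 (0.17 log units; within the scatter) and so does not separate these two halogen-bearing aryl groups. Against the 4-methoxyphenyl group, 2,4-difluorophenyl gives a 2.8-fold higher number from compound 1 to compound 3 (0.45 log units; beyond the scatter) in the same direction as a 4.2-fold higher number from compound 1 to compound 2 (0.63 log units; beyond the scatter) and thus leaves compound 1 with the lowest number of the three, with both steps beyond the scatter. Nothing available accounts for this gap between compound 1 and the two halogen-bearing compounds.

The compounds shown leave open whether the lower number of compound 1 is specific to methoxy or extends to other groups on that aryl ring, such as hydroxy, ethoxy or dimethylamino. They also leave open where an unsubstituted phenyl group would stand relative to these three compounds.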